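A few compounds are considered here, and "the series" means these few. Any claim that something is new, unique, unknown or untested is made for them only; others in the source may bear on it.

Compound 3 `CCOc1ccc(-c2ccccc2)cc1` is the shared core without a sulfonamide. In an assay on COS-7 cells for inhibition of patatin-like phospholipase domain-containing protein 2 (Mus musculus) (on this read-out higher numbers stand for weaker inhibition and lower numbers for stronger inhibition), compound 3 reaches only the limit of the assay, > 200000 nM, so its standing among the measured values is a limit. Compound 1 `CCNS(=O)(=O)c1cccc(-c2ccc(OCC)cc2)c1` gives 200000 nM in this assay. Compound 2 `CCOc1ccc(-c2cccc(S(=O)(=O)NC)c2)cc1` gives 200000 nM in this assay. no change at the digits printed from compound 1 to compound 2 (within the scatter). Compound 4 `CCOc1ccc(-c2cccc(C(=O)O)c2)cc1` differs from compound 3 by carboxy in place of hydrogen on an aromatic carbon. Among the measured compounds shown here, the steps that bear on this are a number no lower from compound 1 to compound 3 (the limit leaves the size open) and a number no lower from compound 2 to compound 3 (the limit leaves the size open); both end at the limit, and the size of either cannot be read. For the measured compounds named here, no measured step introduces a carboxy group. The expectation is therefore a number no higher from compound 3 to compound 4 (the limit leaves the size open), most likely another limit. Compound 4 is estimated at 200000 nM in this assay, within 100000 nM to 400000 nM.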

Compound 4, half-maximal inhibitory concentration: > 200000 nM
Compound 4 ended at the assay's limit; the forecaster's own chance of this, stated with the estimate: 70%; the middle value lies on the limit itself.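

In this assay compound 4 is a limit, > 200000 nM. The values show a number no lower from compound 2 to compound 4 (the limit leaves the size open) and a number no lower from compound 1 to compound 4 (the limit leaves the size open). A carboxy group on this aromatic carbon therefore gives no readable value on the shared core, unlike the ethylsulfamoyl and methylsulfamoyl groups at the same place in compound 1 and compound 2, and the size of all three new steps cannot be read. Compound 3 and compound 4 end at the same point: the limit of > 200000 nM in this assay, at which 2 of the 4 values shown sit.

On these data alone, whether any group at this place gives a value clearly stronger than those of compound 1 and compound 2 stays open. An amine, a primary amide or a longer chain on the sulfonamide nitrogen would test this.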